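Swapping an acetylphenyl for a methoxyphenyl on a shared core

A few compounds are considered here, and "the series" means these few. Any claim that something is new, unique, unknown or untested is made for them only; others in the source may bear on it.

Of the compounds shown here, three sharing one core have been measured in a functional assay on RPMI-8226 cells (Homo sapiens) for inhibition, read by sulforhodamine B assay, with a stated time of 48 h, tested at 10 uM; a higher number here means more inhibition at the concentration tested (going by the name of the read-out), a lower number less inhibition. Compound 1 `c1ccc(-c2cn3ccnc3c(-c3ccc4ncn(C5CCCCC5)c4c3)n2)cc1` gives 85.7%. Compound 2 `COc1ccc(-c2cn3ccnc3c(-c3ccc4ncn(C5CCCCC5)c4c3)n2)cc1`, which carries a methoxy group, gives 95.6%, and the step of a number 9.9 percentage points higher from compound 1 to compound 2 (within the scatter) lies within the scatter. Compound 3 `CC(=O)c1ccc(-c2cn3ccnc3c(-c3ccc4ncn(C5CCCCC5)c4c3)n2)cc1`, which carries an acetyl group, gives 20.8%, the lowest of the three numbers; its nearest neighbour is compound 1, and the step of a number 64.9 percentage points lower from compound 1 to compound 3 (beyond the scatter) is large.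

Compound 4 `COc1ccccc1-c1cn2ccnc2c(-c2ccc3ncn(C4CCCCC4)c3c2)n1` differs from compound 3 in one place: 2-methoxyphenyl in place of 4-acetylphenyl on an aromatic carbon. Within the data shown here, two measured steps bear on this change. The step of a number 74.8 percentage points lower from compound 2 to compound 3 (beyond the scatter) shows that replacing a methoxy with an acetyl on this ring lowered inhibition strongly, and the step of a number 64.9 percentage points lower from compound 1 to compound 3 (beyond the scatter) shows that the acetyl alone accounts for most of that loss. Compound 4 removes the acetyl and brings a methoxy back, so a large rise is expected. Among the measured compounds shown here, the methoxy in compound 4 belongs to a 2-methoxyphenyl rather than the 4-methoxyphenyl of compound 2, and no measured pair speaks to that difference, so the range is kept wide.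

For compound 4, the expected step is a number 59.2 percentage points higher from compound 3 to compound 4 (beyond the scatter), giving an estimate of 80%, between 50% and 97%.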

Compound 4, a percentage reported as inhibition, at one concentration (the size of the read-out at that concentration, not a potency): 35.9%
Compound 4: middle estimate off by 44.1 percentage points, on the high side, and the stated range ends above it.
By their numbers in this assay, from the lowest: compound 3; then compound 4; then compounds 1 and 2 (each within the scatter of the next).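

The position of the methoxy on the outer ring turns out to matter as much as its presence: the step of a number 59.7 percentage points lower from compound 2 to compound 4 (beyond the scatter) comes from nothing more than exchanging 4-methoxyphenyl for 2-methoxyphenyl. The same group therefore behaves differently in its two placements, since adding it as in compound 2 gave a change within the scatter, whereas adding it as in compound 4 gives the step of a number 49.8 percentage points lower from compound 1 to compound 4 (beyond the scatter). Losing the acetyl is also no guarantee of recovery, as the step of a number 15.1 percentage points higher from compound 3 to compound 4 (beyond the scatter) regains only a small part of the inhibition seen with compound 1 and compound 2, so the earlier 4-substituted compounds gave a poor guide to this change.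

No measurement at hand explains why moving the methoxy costs so much inhibition. From the compounds shown here alone, it remains open whether the loss belongs to the methoxy itself or to any group in that place, a question that an amine or a fluorine in place of the methoxy of compound 4 could help to answer.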